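Piperidine to piperazine on the shared core

A few compounds are considered here, and "the series" means these few. Any claim that something is new, unique, unknown or untested is made for them only; others in the source may bear on it.

Measured so far:
compound 1 `C[C@@H]1CN(c2ccc(-c3n[nH]c4cnc(N5CCCCC5)cc34)cn2)CCN1` — 77 nM
compound 2 `C[C@@H]1CN(c2ccc(-c3n[nH]c4cnc(N5[C@H](C)CCC[C@@H]5C)nc34)cn2)CCN1` — 2.5 nM

In an assay on Sf9 cells for inhibition of activin receptor type-1 (Homo sapiens), read by HTRF, with a stated time of 3 h, in the presence of a further agent that is not named here (a lower number here means a stronger inhibitor, a higher number a weaker inhibitor), compound 1 gives 77 nM and compound 2 gives 2.5 nM. Compound 2 has the lowest number of the two, and compound 1 sits a long way above it, beyond the scatter. The two differ in more than one place, so only their two values can be compared.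

Compound 3 `C[C@@H]1CN(c2ccc(-c3n[nH]c4cnc(N5[C@H](C)CNC[C@@H]5C)nc34)cn2)CCN1` is not yet measured. It differs from compound 2 in one place: 2,6-dimethylpiperazin-1-yl in place of 2,6-dimethylpiperidin-1-yl on an aromatic carbon. Among the measured compounds shown here, no measured pair shows this kind of change, so the size of the step is uncertain. The expectation is a modest loss, a 2.0-fold higher number from compound 2 to compound 3 (0.30 log units; within the scatter), possibly no change beyond the scatter. For compound 3 in this assay the estimate is 5 nM, with a range from 1.5 nM to 20 nM.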

Compound 3, half-maximal inhibitory concentration: 793 nM
Compound 3: middle estimate off by 160-fold (2.20 log units), on the low side, and the stated range ends below it.
By their numbers in this assay, from the lowest: compound 2; then compound 1; then compound 3.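

In this assay the aromatic carbon between two ring nitrogen atoms proves highly sensitive to a single ring-atom exchange: 2,6-dimethylpiperazin-1-yl in place of 2,6-dimethylpiperidin-1-yl gives a 320-fold higher number from compound 2 to compound 3 (2.50 log units; beyond the scatter) and this is a large step. The two groups have the same heavy-atom count and two defined stereocentres each, and they differ in one ring carbon exchanged for a nitrogen, with one more hydrogen-bond donor and one more hydrogen-bond acceptor. Nothing available explains why this exchange costs so much.

Open, from the compounds shown here alone, is whether the loss follows the ring nitrogen with its hydrogen or any second hetero atom at that ring place. A 2,6-dimethylmorpholin-4-yl group, with oxygen there, or a 2,4,6-trimethylpiperazin-1-yl group, with a methyl on that nitrogen, would separate these readings.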